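Changing the amide side chain of compound 3

This account rests on a few compounds, and the source may have more. Where it says the series, first, only, none or still open, it means among the compounds named here.

Values measured in a functional assay on MCF7 cells (Homo sapiens) for antiproliferative activity, read by MTT assay, with a stated time of 48 h (a higher number here means a weaker inhibitor, a lower number a stronger inhibitor), are these:
Compound 1 `COC(=O)[C@H](C)NC(=O)c1ccc(Oc2nc3ccc(Cl)cc3nc2C)cc1` gives 33800 nM as a number
Compound 2 `Cc1nc2cc(Cl)ccc2nc1Oc1ccc(C(=O)N[C@@H](CC(C)C)C(=O)O)cc1` gives 17400 nM as a number
Compound 3 `COC(=O)CNC(=O)c1ccc(Oc2nc3ccccc3nc2NC(C)(C)C)cc1` gives > 50000 nM as a limit of the assay

Compound 3 sits at the limit of > 50000 nM in this assay, at which 1 of the 3 values shown sits, and so offers a limit and not a number to start from. Among the compounds with values here, compound 4 `C[C@H](NC(=O)c1ccc(Oc2nc3ccccc3nc2NC(C)(C)C)cc1)C(=O)O` keeps the core of compound 3 and carries 1-carboxyethyl in place of (methoxycarbonyl)methyl on an amide-type nitrogen as its only change.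

Within the data shown here, one measured step bears on this change. It also replaces a group holding a methoxycarbonyl with one holding a carboxy on an amide-type nitrogen, though on a different core and with different chains. That step is a 1.9-fold lower number from compound 1 to compound 2 (0.29 log units; within the scatter) and so stays inside the usual scatter. It is a single pair, which makes it thin support. On the strength of that step, no shift beyond the scatter is expected in this assay in either direction, and compound 4 is expected to remain weak, close to the limit of the assay. The expected size of the change is an at least 1.1-fold lower number from compound 3 to compound 4 (0.07 log units; that floor lies within the scatter) as an estimate only. Compound 4 is estimated at 42000 nM with an expected range from 17000 nM to 70000 nM and may well return only a limit.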

Compound 4, half-maximal inhibitory concentration: 29400 nM
Compound 4: the middle estimate sits 1.4-fold (0.15 log units) above what was measured, within the range that was stated.
By their numbers in this assay, from the lowest: compounds 2, 4 and 1 (each within the scatter of the next). At a limit, above all of these: compound 3.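

In this assay compound 4 gives 29400 nM, so the amide-type nitrogen on the core of compound 3 now has a real number, which compound 3 itself could not supply. Compound 3 stands at a limit and not at a number: the limit of > 50000 nM in this assay, at which 1 of the 4 values shown sits. Within the data shown here, the exchange of (methoxycarbonyl)methyl for 1-carboxyethyl therefore reads as an at least 1.7-fold lower number from compound 3 to compound 4 (0.23 log units; that floor lies within the scatter), which means that only a floor is known for this change on this core, and the actual step may be larger than that floor, whereas the one earlier step of this kind, on another core, had two numbers at its ends and stayed within the scatter.

Compound 3 and compound 4 differ in the ester and the carboxy group and also in the branching of the chain, so the compounds shown leave open how much of the step belongs to each, a question that a plain carboxymethyl group on the same nitrogen would bear on. Also open, from the compounds shown here alone, is what a chain ending in an amine, or a longer chain carrying a carboxylic acid, would give on the core of compound 3.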